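A few compounds are considered here, and "the series" means these few. Any claim that something is new, unique, unknown or untested is made for them only; others in the source may bear on it.

For the measured compounds named here, in a functional assay on HepG2 cells (Homo sapiens) for antiproliferative activity, read by MTT assay, with a stated time of 48 h (on this read-out lower numbers stand for stronger inhibition and higher numbers for weaker inhibition), compound 1 `COc1ccc(-c2c(Nc3ccc(F)cc3)c3ccccc3oc2=O)cc1` gives 35500 nM, the only true number so far. Compound 2 `COc1ccc(-c2c(Nc3ccc(NC(C)=O)cc3)c3ccccc3oc2=O)cc1` reads > 100000 nM, which is a limit of the assay. Compound 3 `COc1ccc(-c2c(Nc3ccc(F)cc3)c3ccc(OC)cc3oc2=O)cc1` keeps the fluoro group of compound 1 and differs by methoxy in place of hydrogen on an aromatic carbon. Going by the values given here, the only measured step, an at least 2.8-fold higher number from compound 1 to compound 2 (0.44 log units; beyond the scatter), replaces the fluoro group, which compound 3 keeps, so it bears only weakly on this change. No step beyond the scatter is therefore expected in this assay, although the uncertainty is wide. The estimated change is a 1.2-fold lower number from compound 1 to compound 3 (0.07 log units; within the scatter). For compound 3, the expected value is 30000 nM, with an estimated range of 10000 nM to 90000 nM.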

Compound 3, half-maximal inhibitory concentration: > 100000 nM
Compound 3 gave a limit, no number; the forecaster's own chance of this, stated with the estimate: 15%; middle value at least 3.3-fold (0.52 log units) from the limit.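

Methoxy in place of hydrogen on this aromatic carbon is not a silent change in this assay: it gives an at least 2.8-fold higher number from compound 1 to compound 3 (0.44 log units; beyond the scatter). Activity can therefore be lost through a change on the fused two-ring part of the core, with the fluoro group left in place, whereas the earlier step changed the fluoro group itself. Compound 3 reads only as a limit, so the real size of this loss stays hidden: the limit of > 100000 nM in this assay, at which 2 of the 3 values shown sit.

On these data alone, whether a hydroxyl group, an amine or a chlorine atom at this same carbon would keep the activity of compound 1 remains open. So does whether methoxy on another carbon of the core would have the same effect.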